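Swapping Phenyl for Thiazolyl in a Histamine Antagonist Series

The source may hold more compounds than are shown below. What is called first, only, known or untested is meant among the compounds shown, and "the series" means these compounds.

Measured so far:
Compound 1, `CC(CC(=O)/N=C(\N)NCCCc1ccc(CN(C)C)o1)c1ccccc1`: 6.52
Compound 2, `CN(C)Cc1ccc(CCCN/C(N)=N/C(=O)CC(c2ccccc2)c2ccccc2)o1`: 7.03

Both compounds were tested in a functional assay on Sf9 cells for antagonist activity at histamine H2 receptor (Homo sapiens), with stated times of 2 min and 20 min; a higher number here means a more potent compound, by a factor of ten per unit of this negative logarithm, a lower number a less potent compound. Among the measured compounds shown here, of the two numbers, compound 2 holds the higher one, and the only other compound, compound 1, sits beyond the scatter below it. For the measured compounds named here, the single measured step, a number 0.51 log units higher from compound 1 to compound 2 (beyond the scatter), comes from phenyl in place of methyl on a saturated chain carbon bound to an aromatic carbon and a saturated chain carbon, a modest gain.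

Compound 3, `CN(C)Cc1ccc(CCCN/C(N)=N/C(=O)CC(c2ccccc2)c2nccs2)o1`, is the next compound and has not yet been measured in this assay. It differs from compound 2 in one place: 1,3-thiazol-2-yl in place of phenyl on a saturated chain carbon bound to an aromatic carbon and a saturated chain carbon. Going by the values given here, no measured step exchanges one ring for another; the one step available concerns adding phenyl where methyl stood, not replacing phenyl by a different ring. That step therefore gives no direction for the present change. With nothing pointing either way, compound 3 is expected to stay close to compound 2, a step of a number 0.13 log units lower from compound 2 to compound 3 (within the scatter) that lies within the scatter. The estimate for compound 3 in this assay is 6.9, expected to fall between 6.3 and 7.5.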

Compound 3, negative logarithm of the antagonist equilibrium constant: 6.13
The estimate for compound 3 lay 0.77 log units above the measured number; the whole stated range lies above it.
By their numbers in this assay, from the lowest: compound 3; then compound 1; then compound 2.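

Within this assay, this result shows that the saturated chain carbon responds to which ring it carries, not just to whether it carries a second ring: putting 1,3-thiazol-2-yl in place of phenyl gives a number 0.90 log units lower from compound 2 to compound 3 (beyond the scatter). The same ring also falls short of the methyl group it could equally replace, with a number 0.39 log units lower from compound 1 to compound 3 (beyond the scatter), so among these compounds the earlier gain belongs to phenyl and does not extend to aromatic rings in general. Nothing measured here bears on the cause of this drop.

The compounds shown leave open whether the drop follows from the change from a six-membered to a five-membered ring or from the nitrogen and sulfur that the new ring brings, a question that thiophen-2-yl or pyridin-2-yl on the same carbon would help to separate. Also open, on these data alone, is whether phenyl, methyl and 1,3-thiazol-2-yl would keep this order on a core with a longer chain in place of the present one.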